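The source may hold more compounds than are shown below. What is called first, only, known or untested is meant among the compounds shown, and "the series" means these compounds.

In a functional assay on KB cells (Homo sapiens) for antiproliferative activity, read by sulforhodamine B assay, with a stated time of 3 days (on this read-out lower numbers stand for an effect already at smaller amounts and higher numbers for an effect only at larger amounts of compound), three compounds with a shared core have been measured so far. Compound 1 `CCC1=C(O)c2c(oc(-c3ccc(C(C)C)cc3)cc2=O)C(CC)(CC)C1=O`, with a 4-isopropylphenyl group, gives 8.13 uM. Compound 3 `CCC1=C(O)c2c(oc(-c3cccc(OC)c3)cc2=O)C(CC)(CC)C1=O`, with a 3-methoxyphenyl group, gives 13.3 uM. These two cannot be told apart, since a 1.6-fold higher number from compound 1 to compound 3 (0.21 log units; within the scatter) stays within the scatter. Compound 2 `CCC1=C(O)c2c(oc(-c3ccc(Br)cc3)cc2=O)C(CC)(CC)C1=O`, with a 4-bromophenyl group, reads > 48.1 uM, which is a limit of the assay and not a number. Compound 3 is thus level with compound 1 and clearly separated from compound 2, as an at least 3.6-fold lower number from compound 2 to compound 3 (0.55 log units; beyond the scatter) shows.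

Compound 4 `CCC1=C(O)c2c(oc(-c3ccccc3OC)cc2=O)C(CC)(CC)C1=O` has the same atoms joined differently: 2-methoxyphenyl in place of 3-methoxyphenyl on an aromatic carbon. Within the data shown here, no measured pair isolates this kind of change. The closest guides are the aryl swaps, which range from a 1.6-fold higher number from compound 1 to compound 3 (0.21 log units; within the scatter) to an at least 5.9-fold higher number from compound 1 to compound 2 (0.77 log units; beyond the scatter), so exchanging this group can matter, but the methoxy-bearing compound 3 stays close to compound 1. No step beyond the scatter is therefore expected, and the estimated change is a 1.1-fold higher number from compound 3 to compound 4 (0.05 log units; within the scatter). Compound 4 is expected to give about 15 uM, with an estimated range of 6 uM to 40 uM.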

Compound 4, concentration for half-maximal effect: 40.8 uM
Estimate against measurement, compound 4: 2.7-fold (0.43 log units) below; measured number above the stated range.
By their numbers in this assay, from the lowest: compounds 1 and 3 (each within the scatter of the next); then compound 4. At a limit, above all of these: compound 2.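

Moving the methoxy group alone, with the same atoms joined differently, leads in this assay to a modest step: a 3.1-fold higher number from compound 3 to compound 4 (0.49 log units; beyond the scatter), so where this group sits on the phenyl ring counts as well as which group it is. Compound 3 could not be told apart from compound 1, whereas the new isomer can, with a 5.0-fold higher number from compound 1 to compound 4 (0.70 log units; beyond the scatter), so a methoxy-bearing phenyl group does not by itself keep a compound level with compound 1. Compound 2 reads only as a limit: the limit of > 48.1 uM in this assay, at which 1 of the 4 values shown sits. The step that remains, an at least 1.1-fold lower number from compound 2 to compound 4 (0.07 log units; that floor lies within the scatter), therefore has a floor that lies within the scatter and does not separate the two.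

On these data alone, whether the same move has a similar effect with another group on the phenyl ring, such as an ethoxy group or an amine, stays open. The compounds shown also give no reason why the 2-methoxyphenyl group reads higher.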